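This account rests on a few compounds, and the source may have more. Where it says the series, first, only, none or still open, it means among the compounds named here.

Three compounds of this series have been examined in an assay on cells for inhibition of S-adenosylmethionine decarboxylase proenzyme (Homo sapiens), read by mass spectrometry, at pH 7.2 (a lower number here means a stronger inhibitor, a higher number a weaker inhibitor), and none of them returned a number. Compound 1, `Cc1cc(Nc2cc(Cl)cc(Cl)c2)ncn1`, reached only the limit of the assay, > 180000 nM. Compound 2, `Cc1cc(Nc2cc(Br)cc(S(F)(F)(F)(F)F)c2)nc(N)n1`, likewise stopped at the limit, > 180000 nM. Compound 3, `CCc1cc(Br)cc(Nc2cc(C)nc(N)n2)c1`, also sits at the limit, > 180000 nM. Among the compounds with values here, the one step that can be drawn between measured structures, a step that the two limits leave unreadable from compound 2 to compound 3, therefore remains without a size, because the limit of > 180000 nM in this assay, at which 3 of the 3 values shown sit, leaves no number on either side of it. Compound 3 thus stands level with the other two at the limit, with nothing in the numbers to set it apart.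

Compound 4, `Cc1cc(Nc2cc(Br)cc(OCC(F)(F)F)c2)nc(N)n1`, differs from compound 3 in one place: 2,2,2-trifluoroethoxy in place of ethyl on an aromatic carbon. Within the data shown here, no measured step gives a readable size for this exchange; the only step measured so far is bounded on both sides and tells neither direction nor magnitude. The expectation for compound 4 is therefore that it stays where compound 3 stands, with a step that the limit leaves unreadable from compound 3 to compound 4 that is expected to be none beyond the scatter. Compound 4 is estimated at 300000 nM, within a range from 100000 nM to 1000000 nM, and most likely it will again be reported only as a limit.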

Compound 4, half-maximal inhibitory concentration: 44000 nM
Compound 4: middle estimate off by 6.8-fold (0.83 log units), on the high side; measured number below the stated range.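

In this assay, within the data shown here, the position on the aromatic carbon meta to a bromo group now yields a number for the first time: 2,2,2-trifluoroethoxy in place of ethyl gives an at least 4.0-fold lower number from compound 3 to compound 4 (0.61 log units; beyond the scatter). The group of five fluorines and one sulfur in compound 2 has the same number of heavy atoms as 2,2,2-trifluoroethoxy, yet exchanging it gives an at least 4.0-fold lower number from compound 2 to compound 4 (0.61 log units; beyond the scatter), so heavy-atom count alone does not set these compounds apart. Both steps are minimum sizes, with a number at only one end: the limit of > 180000 nM in this assay, at which 3 of the 4 values shown sit.

The compounds shown leave open whether a plain ethoxy group would also return a number, or whether the three fluorines are needed. On these data alone, how an amine or a longer fluorinated ether chain would read at this position also remains open.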